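Amine variation at the propyl-bearing core of the cinnamamide series

This account rests on a few compounds, and the source may have more. Where it says the series, first, only, none or still open, it means among the compounds named here.

Measured so far:
compound 1, `CCCc1cc(N2CCCC2)c2cc(NC(=O)/C=C/c3ccc(C(F)(F)F)cc3)ccc2n1`, 2800 nM
compound 2, `CCCc1cc(N2CCC2)c2cc(NC(=O)/C=C/c3ccc(C(F)(F)F)cc3)ccc2n1`, 2500 nM

Both numbers come from a functional assay on HEK293 cells for activation of melanin-concentrating hormone receptor 1 (Homo sapiens), read by inositol phosphate accumulation; a lower number here means that less compound is needed, a higher number that more compound is needed for the effect. Among the measured compounds shown here, the only measured step, a 1.1-fold lower number from compound 1 to compound 2 (0.05 log units; within the scatter), stays within the scatter, so compound 2 and compound 1 cannot be ordered; compound 2 simply carries the lower of the two numbers.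

Compound 3, `CCCc1cc(NC)c2cc(NC(=O)/C=C/c3ccc(C(F)(F)F)cc3)ccc2n1`, differs from compound 2 in one place: methylamino in place of azetidin-1-yl on an aromatic carbon. For the measured compounds named here, no measured step covers the loss of the ring itself or the arrival of a hydrogen-bond donor; the ring contraction seen in the step from compound 1 to compound 2 is the only related information, and it caused no shift beyond the scatter. On that basis a small step is expected for compound 3, a 1.4-fold higher number from compound 2 to compound 3 (0.15 log units; within the scatter), leaning toward a higher number. The estimate for compound 3 in this assay is 3500 nM, with a range from 1200 nM to 10000 nM.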

Compound 3, half-maximal effective concentration: 150 nM
Estimate against measurement, compound 3: 23-fold (1.37 log units) above, and the stated range ends above it.
By their numbers in this assay, from the lowest: compound 3; then compounds 2 and 1 (each within the scatter of the next).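

In this assay this position proves sensitive to the amine: a 17-fold lower number from compound 2 to compound 3 (1.22 log units; beyond the scatter) and a 19-fold lower number from compound 1 to compound 3 (1.27 log units; beyond the scatter) are both large, whereas the change in ring size between the two cyclic amines stayed within the scatter. Methylamino differs from both cyclic amines in three ways at once, with no ring, fewer heavy atoms and a hydrogen-bond donor, and these compounds do not separate the three. No measurement at hand accounts for the size of these steps.

The compounds shown leave open whether the donor or the loss of the ring matters more, a question that dimethylamino on the same aromatic carbon would bear on. Also open, going by these compounds, is how the series responds to a plain amino group or to a longer chain on the nitrogen, such as ethylamino.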